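Ether size and unbound fraction in a small amide series

A few compounds are considered here, and "the series" means these few. Any claim that something is new, unique, unknown or untested is made for them only; others in the source may bear on it.

compound 1 `CCCOc1ccc(C(=O)Nc2cc(OC(F)(F)F)ccc2-n2cncn2)cc1OC` gives 0.019
compound 2 `COc1cc(C(=O)Nc2cc(OC(F)(F)F)ccc2-n2cncn2)ccc1OC1CC1` gives 0.039
compound 3 `COc1ccc(C(=O)Nc2cc(OC(F)(F)F)ccc2-n2cncn2)cc1OC` gives 0.178

In an ADME assay on a cell-free system (plasma, Mus musculus) for protein binding, read by LC-MS, using equilibrium dialysis, with a stated time of 4 h (a higher number here means a larger unbound share of the compound, a lower number a smaller unbound share), compound 2, at 0.039, is second highest of the three numbers. The next point is compound 4 `CCOc1ccc(C(=O)Nc2cc(OC(F)(F)F)ccc2-n2cncn2)cc1OC`, still unmeasured. Its difference from compound 2 is ethyl in place of cyclopropyl on an oxygen on an aromatic ring, which reads as cyclopropyloxy to ethoxy.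

Among the compounds with values here, no measured step makes this exact exchange, but three bear on it. Methyl in place of cyclopropyl on the same oxygen gives a 4.6-fold higher number from compound 2 to compound 3 (0.66 log units; beyond the scatter). Cyclopropyl in place of propyl gives a 2.1-fold higher number from compound 1 to compound 2 (0.31 log units; beyond the scatter). Methyl in place of propyl gives a 9.4-fold higher number from compound 1 to compound 3 (0.97 log units; beyond the scatter). Ethyl is expected to fall inside that last span, nearer its lower end than its upper end, and so close to compound 2 in this assay. The estimated change is a 1.5-fold higher number from compound 2 to compound 4 (0.19 log units; within the scatter), a small rise that is not expected to clear the scatter. For compound 4 the estimated value is 0.06, with an expected range from 0.03 to 0.11.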

Compound 4, unbound fraction: 0.086
The estimate for compound 4 lay 1.4-fold (0.16 log units) below the measured number; low and high end bracket the measured number.
By their numbers in this assay, from the lowest: compound 1; then compound 2; then compound 4; then compound 3.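

In this assay, within the data shown here, the straight chains on this oxygen now form a complete series: shortening propyl to ethyl gives a 4.5-fold higher number from compound 1 to compound 4 (0.66 log units; beyond the scatter), and adding a methyl to the methyl ether gives a 2.1-fold lower number from compound 3 to compound 4 (0.32 log units; beyond the scatter), so each chain carbon moves the unbound fraction beyond the scatter, with no straight-chain compound against the trend. Cyclopropyl is not interchangeable with ethyl here, as ethyl in its place gives a 2.2-fold higher number from compound 2 to compound 4 (0.34 log units; beyond the scatter). Among these ethers, compound 2 therefore falls between the ethyl and propyl compounds, outside the order of the straight chains.

On these data alone, whether a butyl chain, a branched isopropyl group or a cyclobutyl ring would continue this order, or an amine on the chain would break it, remains open. No measurement available here accounts for these steps.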